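Amide nitrogen methylation in a nucleoside carboxamide series

The source may hold more compounds than are shown below. What is called first, only, known or untested is meant among the compounds shown, and "the series" means these compounds.

Measured so far in an assay on CHO cells for displacement of a labelled ligand from adenosine receptor A3 (Homo sapiens); on this read-out lower numbers stand for stronger inhibition and higher numbers for weaker inhibition:
- compound 1 `CNC(=O)[C@H]1O[C@@H](n2cnc3c(N)nc(Cl)nc32)[C@H](O)[C@@H]1O` gives 0.398 nM
- compound 2 `CNC(=O)[C@H]1O[C@@H](n2cnc3c(NC)nc(Cl)nc32)[C@H](O)[C@@H]1O` gives 0.282 nM

Compound 2 has the lowest of the two numbers in this assay; its nearest neighbour is compound 1, and the step of a 1.4-fold lower number from compound 1 to compound 2 (0.15 log units; within the scatter) is within the scatter, so the two cannot be ordered.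

Compound 3 `CNc1nc(Cl)nc2c1ncn2[C@@H]1O[C@H](C(=O)N(C)C)[C@@H](O)[C@H]1O` is the next member. It differs from compound 2 by methyl in place of hydrogen on an amide-type nitrogen; seen one bond further out, the methylcarbamoyl becomes dimethylcarbamoyl while the methylamino on the shared core is kept.

Among the measured compounds shown here, only one measured step exists, from compound 1 to compound 2, and it places a methyl on a nitrogen on an aromatic ring, a different place from the amide-type nitrogen changed here; it was within the scatter. For the measured compounds named here, no measured step touches the amide-type nitrogen, so there is no direct precedent for the direction or size of the change, and the uncertainty around any figure is wide.

On that basis compound 3 is expected to come out at 5 nM in this assay, within a range of 0.5 nM to 50 nM; the implied step an 18-fold higher number from compound 2 to compound 3 (1.25 log units; beyond the scatter) is an estimate, not a measured result.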

Compound 3, inhibition constant: 1510 nM
For compound 3 the middle estimate is 300-fold (2.48 log units) below the measured one; measured number outside the range, above it.
By their numbers in this assay, from the lowest: compounds 2 and 1 (each within the scatter of the next); then compound 3.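

Methyl in place of hydrogen on an amide-type nitrogen is the first change in this series to move this assay well beyond the scatter: a 5400-fold higher number from compound 2 to compound 3 (3.73 log units; beyond the scatter), whereas the same replacement on a nitrogen on an aromatic ring gave a 1.4-fold lower number from compound 1 to compound 2 (0.15 log units; within the scatter), which is within the scatter. The series is therefore not indifferent to methylation as such, and in these compounds the outcome depends on which nitrogen carries the new methyl, with methylcarbamoyl giving a far lower number than dimethylcarbamoyl on the same methylamino core. No measurement at hand accounts for the size of this step, so the result stands as an observation on one matched pair without an established cause.

Still open, from the compounds shown here alone, is how the number responds to other groups at this amide-type nitrogen, such as an ethyl group or a cyclopropyl ring in place of the methyl, or the unsubstituted primary carboxamide carrying two hydrogens. Equally open, going by these compounds, is whether dimethylcarbamoyl on the core of compound 1, which carries an amino group instead of methylamino, would bring a step of similar size.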